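The source may hold more compounds than are shown below. What is called first, only, known or untested is meant among the compounds shown, and "the series" means these compounds.

Working notes on the series, all of whose members are tested in an ADME assay on RAW264.7 cells (Mus musculus) for cytotoxicity, read by MTT assay, with a stated time of 48 h; a lower number here means a stronger inhibitor, a higher number a weaker inhibitor. Of the compounds shown here, two carry measured values so far. Compound 1 `O=C(NCCOC(=S)Nc1ccc([N+](=O)[O-])cc1Cl)c1cccnc1` reports only a limit of the assay in this assay, namely > 800000 nM. Compound 2 `Cc1ccc(NC(=S)OCCNC(=O)C(C)(C)Oc2ccc(Cl)cc2)cc1` likewise gives only a limit in this assay, namely > 800000 nM. Within the data shown here, compound 2 thus stands at the same limit as the one further value shown, so no ordering between the two is possible; both sit at the limit of > 800000 nM in this assay, at which 2 of the 2 values shown sit. Among the measured compounds shown here, no step between measured compounds differing in one place is available, so the size of a single structural change has not yet been observed in this assay.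

Compound 3 `CC(C)(Oc1ccc(Cl)cc1)C(=O)NCCOC(=S)Nc1ccccc1` is the next member to be measured. It differs from compound 2 by hydrogen in place of methyl on an aromatic carbon. With both recorded values resting at the limit of > 800000 nM in this assay, at which 2 of the 2 values shown sit, the expected step in this assay is none beyond the scatter, a number no higher from compound 2 to compound 3 (the limit leaves the size open). Compound 3 is therefore estimated at 800000 nM in this assay, with a range from 400000 nM to 1600000 nM, and most probably only a limit will again be reported.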

Compound 3, half-maximal inhibitory concentration: > 800000 nM
Compound 3: a limit, no number (the forecaster's own chance of this, stated with the estimate: 85%); the middle value sits exactly at the limit.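

In this assay compound 3 gives only a limit, > 800000 nM. No step can be read from compound 2 to compound 3, because both rest at the same limit: the limit of > 800000 nM in this assay, at which 3 of the 3 values shown sit.

The compounds shown leave open what size the change from 4-methylphenyl to phenyl has, and which structure would give a readable number in this assay.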